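A few compounds are considered here, and "the series" means these few. Any claim that something is new, unique, unknown or untested is made for them only; others in the source may bear on it.

Measured so far:
compound 1 `Cc1ccc(C(=O)Nc2cccc(NC(=O)COc3ccc4c(=O)ccoc4c3)c2)cc1` — in an assay on isolated protein for inhibition of Rho-associated protein kinase 2 (Homo sapiens), read by scintillation counting, radiometric assay and 33P incorporation, with a stated time of 40 min, in the presence of a further agent that is not named here (on this read-out lower numbers stand for stronger inhibition and higher numbers for weaker inhibition), compound 1 gives 22 nM
compound 2 `Cc1cc(C(=O)Nc2cccc(NC(=O)COc3ccc4c(=O)ccoc4c3)c2)no1` — in this assay compound 2 gives 5 nM

Compound 2 holds the lower of the two numbers in this assay; the change on the shared core of compound 1 gave a 4.4-fold lower number from compound 1 to compound 2 (0.64 log units; beyond the scatter). Compound 3 `Nc1ccc(C(=O)Nc2cccc(NC(=O)COc3ccc4c(=O)ccoc4c3)c2)cc1` is not yet measured in this assay. It differs from compound 2 by 4-aminophenyl in place of 5-methyl-1,2-oxazol-3-yl on a carbonyl carbon. Going by the values given here, the only measured step that bears on this is a 4.4-fold lower number from compound 1 to compound 2 (0.64 log units; beyond the scatter), which moved away from one six-membered aromatic ring of carbon only; compound 3 returns to such a ring, so a modest step back toward the number of compound 1 is expected, a 3.0-fold higher number from compound 2 to compound 3 (0.48 log units; beyond the scatter). For compound 3 in this assay the estimate is 15 nM, range 5 nM to 45 nM.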

Compound 3, half-maximal inhibitory concentration: 83 nM
Compound 3: the middle estimate sits 5.5-fold (0.74 log units) below what was measured; measured number above the stated range.
By their numbers in this assay, from the lowest: compound 2; then compound 1; then compound 3.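

In this assay, going from 5-methyl-1,2-oxazol-3-yl to 4-aminophenyl on the carbonyl carbon gives a 17-fold higher number from compound 2 to compound 3 (1.22 log units; beyond the scatter), a large step that does not stop at the level of compound 1. The two groups on a six-membered aromatic ring of carbon only also part: amino in place of methyl on an aromatic carbon gives a 3.8-fold higher number from compound 1 to compound 3 (0.58 log units; beyond the scatter), so the ring alone does not set the number. No measurement here accounts for either step.

Open, from the compounds shown here alone, is whether a hydroxyl or a methoxy in place of the amino would follow methyl or amino. Also open, going by these compounds, is whether an ethyl or an amine in place of the methyl on the 1,2-oxazole ring would hold the number of compound 2.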